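This account rests on a few compounds, and the source may have more. Where it says the series, first, only, none or still open, it means among the compounds named here.

Measured so far in an ADME assay on cells (Hepatocyte, Rattus norvegicus) for pharmacokinetics, read by LC-MS, with a stated time of 90 min, tested at 1 uM; on this read-out higher numbers stand for fast clearance and lower numbers for slow clearance:
- compound 1 `CCN(C(=O)OC)c1c(N)nc(-c2nn(Cc3ccccc3F)c3ncccc23)nc1N`: 11.7 mL/min/kg
- compound 2 `COC(=O)N(Cc1cccc(F)c1)c1c(N)nc(-c2nn(Cc3ccccc3F)c3ncccc23)nc1N`: 53.3 mL/min/kg

For the measured compounds named here, compound 2, at 53.3 mL/min/kg, holds the higher of the two numbers, and compound 1 is its only comparison. The next compound is compound 3 `COC(=O)N(Cc1ccc(F)cc1)c1c(N)nc(-c2nn(Cc3ccccc3F)c3ncccc23)nc1N`, and its difference from compound 2 reads (4-fluorophenyl in place of 3-fluorophenyl on a saturated chain carbon bound to an amide-type nitrogen). In words, this is 4-fluorophenyl in place of 3-fluorophenyl on a saturated chain carbon bound to an amide-type nitrogen.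

Going by the values given here, only one measured step bears on this change: a 4.6-fold higher number from compound 1 to compound 2 (0.66 log units; beyond the scatter). That step placed 3-fluorophenyl where methyl had been, so it exchanged one group for a quite different one. The change to compound 3 keeps the same atoms, joined differently. Among the compounds with values here, no measured pair isolates this kind of change, so its size cannot be read directly from the data. The modest step from methyl gives no reason to expect a larger one here, and none beyond the scatter is expected in this assay. The expected change is a 1.1-fold lower number from compound 2 to compound 3 (0.05 log units; within the scatter). For compound 3 the estimate is 48 mL/min/kg, with an expected range of 27 mL/min/kg to 85 mL/min/kg.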

Compound 3, clearance: 40 mL/min/kg
The estimate for compound 3 lay 1.2-fold (0.08 log units) above the measured number, and the stated range covers the measured number.
By their numbers in this assay, from the lowest: compound 1; then compounds 3 and 2 (each within the scatter of the next).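

In this assay, 4-fluorophenyl in place of 3-fluorophenyl on a saturated chain carbon bound to an amide-type nitrogen gives a 1.3-fold lower number from compound 2 to compound 3 (0.12 log units; within the scatter), so this exchange of the same atoms cannot be told apart from repeat-measurement variation. The step from methyl now has a second reading, a 3.4-fold higher number from compound 1 to compound 3 (0.53 log units; beyond the scatter), which runs in the same direction as a 4.6-fold higher number from compound 1 to compound 2 (0.66 log units; beyond the scatter) and places both fluorophenyl compounds clear of compound 1 on this read-out. No measured information accompanies these numbers that would account for the gap between the methyl and fluorophenyl compounds.

Still open, from the compounds shown here alone, is whether that gap follows the fluorine, the aromatic ring or simply the larger group, which a plain benzyl group and a propyl chain on the same nitrogen would help to separate. Also open, going by these compounds, is how far this position tolerates other kinds of group, such as a chain ending in an amine or a carboxylic acid, and whether the small difference between the two fluorophenyl compounds would hold for other ring substituents, such as methoxy or chloro.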